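From Phenoxy to Benzyl: Estimating Compound 4

A few compounds are considered here, and "the series" means these few. Any claim that something is new, unique, unknown or untested is made for them only; others in the source may bear on it.

Measured compounds:
- compound 1 `COc1ccc(Oc2ccc3cc(NC(=O)c4ccc(OC(C)=O)c(CC=C(C)C)c4)c(=O)oc3c2C)cc1` — 19500 nM
- compound 2 `COc1ccc(Oc2ccc3cc(NC(=O)c4ccc(O)c(CC=C(C)C)c4)c(=O)oc3c2C)cc1` — 42700 nM
- compound 3 `COc1cccc(-c2cc(C(=O)Nc3cc4ccc(Oc5ccc(C(C)(C)C)cc5)c(C)c4oc3=O)ccc2OC)c1` — a limit, > 100000 nM

Of the compounds shown here, three sharing one core have been tested in a functional assay on SK-BR-3 cells (Homo sapiens) for antiproliferative activity; a higher number here means a weaker inhibitor, a lower number a stronger inhibitor. Compound 1 gives 19500 nM. Compound 2, which carries a hydrogen in place of the acetyl on the ring oxygen, gives 42700 nM; that single change is the step of a 2.2-fold higher number from compound 1 to compound 2 (0.34 log units; beyond the scatter). Compound 3 reached only the limit of this assay, (the limit of > 100000 nM in this assay, at which 1 of the 3 values shown sits), so no number is known for it. Among the two numbers that exist, compound 1 stands at the lower, stronger end.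

Compound 4 `COc1ccc(Cc2ccc3cc(NC(=O)c4ccc(OC(C)=O)c(CC=C(C)C)c4)c(=O)oc3c2C)cc1` has not yet been measured. It differs from compound 1 in one place: 4-methoxybenzyl in place of 4-methoxyphenoxy on an aromatic carbon. Within the data shown here, the only measured step, from compound 1 to compound 2, concerns the acetyl group on the other side of the molecule and says nothing about exchanging the phenoxy linker for a benzyl one. Among the measured compounds shown here, no measured step therefore bears on this change, and there is no ground to expect a shift in this assay beyond the usual scatter in either direction.

Compound 4 is expected to land close to compound 1, around 22000 nM, with a plausible range from 8000 nM to 70000 nM. The expected step from compound 1 to compound 4 is thus a 1.1-fold higher number from compound 1 to compound 4 (0.05 log units; within the scatter), essentially flat.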

Compound 4, half-maximal inhibitory concentration: 23500 nM
The estimate for compound 4 lay 1.1-fold (0.03 log units) below the measured number, within the range that was stated.
By their numbers in this assay, from the lowest: compounds 1, 4 and 2 (each within the scatter of the next, the first and the last beyond it). At a limit, above all of these: compound 3.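

In this assay, putting 4-methoxybenzyl in place of 4-methoxyphenoxy on this aromatic carbon, ortho to a methyl group, gives a 1.2-fold higher number from compound 1 to compound 4 (0.08 log units; within the scatter), so the two compounds cannot be told apart here. The earlier step touched only the acetyl at the far end of the molecule, whereas this pair is the only one shown that tests this position, and it shows that a group with fewer hydrogen-bond acceptors and one carbon more can stand here with no change beyond the scatter. Nothing measured here explains why the two groups read alike in this assay.

Going by these compounds, a single pair says little about the position as a whole, so it remains open whether a linking amine, a longer chain between the two rings, or a carboxylic acid in place of the methoxy group would be tolerated as well. On these data alone, it is also open whether removing the acetyl from compound 4 to leave a free hydroxyl group would give a step like the one between the acetyl and hydrogen forms in the phenoxy pair.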